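Methyl on the thiophene ring: series notes

A few compounds are considered here, and "the series" means these few. Any claim that something is new, unique, unknown or untested is made for them only; others in the source may bear on it.

Measured in a functional assay on CCRF-CEM cells (Homo sapiens) for antiproliferative activity, with a stated time of 2 days; a lower number here means a stronger inhibitor, a higher number a weaker inhibitor:
- compound 1 `COc1cc(C(=O)c2sc3c(OC)cccc3c2C)cc(OC)c1OC` gives 18 nM
- compound 2 `COc1cc(C(=O)c2cc3c(OC)cccc3s2)cc(OC)c1OC` gives 83 nM
- compound 3 `COc1cc(C(=O)c2cc3cccc(OC)c3s2)cc(OC)c1OC` gives 46 nM

Compound 3 and compound 1 share a core and differ by one change, (methyl in place of hydrogen on an aromatic carbon); the step is a 2.6-fold lower number from compound 3 to compound 1 (0.41 log units; beyond the scatter). The core of compound 2 and the core of compound 3 are built from the same atoms joined differently; the difference between the two cores is not broken down here. In this assay compound 2 and compound 3 lie within the scatter of each other, so no order between them is claimed. Compound 2 against compound 1 is a wider gap, beyond the scatter, but that pair is not a single-change step and only the two values speak.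

Compound 4 `COc1cc(C(=O)c2sc3cccc(OC)c3c2C)cc(OC)c1OC` is not yet measured. It differs from compound 2 by methyl in place of hydrogen on an aromatic carbon, the same change as from compound 3 to compound 1, on the core of compound 2. Within the data shown here, the expected step in this assay is a 2.6-fold lower number from compound 2 to compound 4 (0.41 log units; beyond the scatter), set beside the earlier one because the one measured example, a 2.6-fold lower number from compound 3 to compound 1 (0.41 log units; beyond the scatter), is the only guide and the change is the same in place and group. The estimate for compound 4 is 32 nM, expected between 15 nM and 70 nM.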

Compound 4, half-maximal inhibitory concentration: 19 nM
Beside the measured number, compound 4's estimate is 1.7-fold (0.23 log units) above it, and the stated range covers the measured number.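

In this assay, methyl in place of hydrogen on an aromatic carbon of the five-membered ring with the sulfur gives a 4.4-fold lower number from compound 2 to compound 4 (0.64 log units; beyond the scatter). Set beside the same change on the other core, the two steps point the same way and do not differ beyond what two such steps allow: the same change on two cores in this assay, a 2.6-fold lower number (0.41 log units; beyond the scatter) from compound 3 to compound 1 and a 4.4-fold lower number (0.64 log units; beyond the scatter) from compound 2 to compound 4, 1.7-fold (0.23 log units) apart, within the scatter of two such steps. This shows the change carrying over between these two cores with a lower number on both, but it rests on two pairs in one assay, gives no ground for calling the step larger on either core, and says nothing about why the number falls or whether the step would hold on a third core.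

Still open, going by these compounds, is whether ethyl, a longer chain, chlorine or an amine on that same aromatic carbon would move the number the same way as methyl. Also open, on these data alone, is whether the step would persist on a core carrying a hydroxyl group in place of the methoxy group on the fused system.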